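The source may report more compounds than this note shows. Statements on the series, on what has been measured and on what is new or still open speak of the compounds shown alone.

Measured compounds:
compound 1, `Cc1ccc(-c2ccc(C(O)CCCCCO)cc2)cc1`, 22000 nM
compound 2, `OCCCCCC(O)c1ccc(-c2ccc(Cl)cc2)cc1`, 17000 nM
compound 3, `Cc1cc(-c2ccc(F)cc2F)ccc1C(=O)CCCCCO`, 4000 nM

These three were tested in a functional assay on J774 cells (Mus musculus) for cytotoxicity, read by resazurin assay; a higher number here means a weaker inhibitor, a lower number a stronger inhibitor. Compound 1 and compound 2 share one core, and compound 2 carries the change (chloro in place of methyl on an aromatic carbon). That change gave a 1.3-fold lower number from compound 1 to compound 2 (0.11 log units; within the scatter), a step that the usual scatter of repeated measurements can account for. Compound 3 has a different core; how the two cores differ is not broken down here. Compound 3 gives the lowest of the three numbers, and compound 2 is the nearest to it.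

Compound 4, `O=C(CCCCCO)c1ccc(-c2ccc(F)cc2F)cc1Cl`, has not been measured. Compared with compound 3 it carries chloro in place of methyl on an aromatic carbon. Among the compounds with values here, this is the same kind of change as the one from compound 1 to compound 2, but not the same: in compound 2 the chloro sits para to a large group, whereas in compound 4 it sits ortho to a group of 8 heavy atoms and meta to a group of 8 heavy atoms.

The step from compound 3 to compound 4 is expected to be small, a 1.1-fold lower number from compound 3 to compound 4 (0.06 log units; within the scatter), because a 1.3-fold lower number from compound 1 to compound 2 (0.11 log units; within the scatter) stayed within the scatter. Compound 4 is therefore estimated at 3500 nM in this assay, likely between 1500 nM and 8000 nM.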

Compound 4, half-maximal inhibitory concentration: 7000 nM
Compound 4: middle estimate off by 2.0-fold (0.30 log units), on the low side; measured number inside the range.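

Replacing methyl with chloro on an aromatic carbon gave a 1.8-fold higher number from compound 3 to compound 4 (0.24 log units; within the scatter) in this assay, so on this second core the step again stays small. For a newcomer, the useful check is whether the same swap behaves alike on both cores, and here the two steps cannot be told apart: the same change on two cores in this assay, a 1.3-fold lower number (0.11 log units; within the scatter) from compound 1 to compound 2 and a 1.8-fold higher number (0.24 log units; within the scatter) from compound 3 to compound 4, 2.3-fold (0.36 log units) apart, within the scatter of two such steps. This shows that, across these two pairs, the earlier step gave a fair guide to the size of the new one, but it does not show that the swap would stay this small on every core in the series, and with both steps inside the scatter, neither gives a dependable direction for the change.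

The compounds shown leave open whether a different group on that aromatic carbon, such as an amine, a nitrile or a carboxylic acid, would move the number beyond the scatter. They also leave open what a longer chain would do on either core.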